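One Substituent Swap and an Expected Cytotoxicity Value

The source may report more compounds than this note shows. Statements on the series, on what has been measured and on what is new or still open speak of the compounds shown alone.

Of the compounds shown here, two have been measured so far. Compound 1 `COc1ccc(NC(=O)COC(=O)/C=C/c2ccc(OCc3ccccc3)c(O)c2)cc1` in a functional assay on HL-60 cells (Homo sapiens) for cytotoxicity, read by MTT assay, with a stated time of 72 h (on this read-out higher numbers stand for weaker inhibition and lower numbers for stronger inhibition), reaches only a limit, > 200000 nM, which is the edge of what this assay can report rather than a measured number. Among the compounds with values here, compound 2 `O=C(COC(=O)/C=C/c1ccc(O)c(O)c1)Nc1ccc(Cl)cc1` in this assay gives 8100 nM, the only real number in the set. The other entry, that of compound 1, is a limit (the limit of > 200000 nM in this assay, at which 1 of the 2 values shown sits).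

The step to the unmeasured compound 3 `COc1ccc(NC(=O)COC(=O)/C=C/c2ccc(O)c(O)c2)cc1` is small and sits on the same shared core as compound 2: methoxy in place of chloro on an aromatic carbon. Within the data shown here, no measured pair in this set differs in only this place, so the size of the step cannot be read off from existing data, and compound 1 differs from compound 3 in a second place as well.

Among the measured compounds shown here, with only one number to anchor on, the expectation for compound 3 is a value close to that of compound 2, with a step of a 1.5-fold higher number from compound 2 to compound 3 (0.17 log units; within the scatter) that is expected to stay within the usual scatter or slightly beyond it toward weaker inhibition. Compound 3 is therefore estimated at 12000 nM, with a plausible range from 4000 nM to 50000 nM.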

Compound 3, half-maximal inhibitory concentration: 72100 nM
Compound 3: middle estimate off by 6.0-fold (0.78 log units), on the low side; measured number outside the range, above it.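

In this assay the aromatic carbon para to a large group proves sensitive, even though the change there is small: methoxy in place of chloro gives an 8.9-fold higher number from compound 2 to compound 3 (0.95 log units; beyond the scatter), the first measured sign that this place on the shared core affects the read-out. The other change, hydrogen in place of benzyl on an oxygen on an aromatic ring, can now also be sized, as an at least 2.7-fold lower number from compound 1 to compound 3 (0.44 log units; beyond the scatter), although this figure sets only a minimum for the step. Compound 1 stands at a limit of the assay rather than at a real number, so the step has no measured upper end: the limit of > 200000 nM in this assay, at which 1 of the 3 values shown sits.

On these data alone, each of these changes rests on a single pair, so it stays open whether either step would keep its size on a different core, and these values give no reason for the difference between chloro and methoxy. Other groups on the same aromatic carbon, such as an amine, a fluoro group or a carboxylic acid, would show whether chloro stands apart or methoxy alone gives the higher number.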